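Compound 4: 1H-imidazol-5-yl in place of pyridin-3-yl

This account rests on a few compounds, and the source may have more. Where it says the series, first, only, none or still open, it means among the compounds named here.

Measured so far in a functional assay on A-431 cells (Homo sapiens), read by propidium iodide staining, with a stated time of 24 h; on this read-out higher numbers stand for an effect only at larger amounts of compound and lower numbers for an effect already at smaller amounts:
- compound 1 `FC(F)(F)c1cccc(-c2nnc(-c3cccnc3NCc3cn[nH]c3)[nH]2)c1` gives > 10000 nM (a limit)
- compound 2 `c1cnc(NCc2ccncc2)c(-c2nnc(Nc3ccc4c(c3)OCCO4)o2)c1` gives 18 nM
- compound 3 `c1cncc(CNc2ncccc2-c2nnc(Nc3ccc4c(c3)OCCO4)o2)c1` gives 13 nM

The entry for compound 1 is a limit and not a number. Compound 3 lies within the scatter of compound 2. Compound 4 `c1cnc(NCc2cnc[nH]2)c(-c2nnc(Nc3ccc4c(c3)OCCO4)o2)c1` carries 1H-imidazol-5-yl in place of pyridin-3-yl on a saturated chain carbon bound to a nitrogen on an aromatic ring. Within the data shown here, the one measured step at this place is a 1.4-fold lower number from compound 2 to compound 3 (0.14 log units; within the scatter) and stays within the scatter. That step only exchanges pyridin-4-yl for pyridin-3-yl, whereas here a six-membered aromatic ring leaves and a five-membered one enters. The expected change in this assay is therefore modest, a 2.3-fold higher number from compound 3 to compound 4 (0.36 log units; beyond the scatter) and uncertain in size. Compound 4 is estimated at 30 nM (expected range 8 nM to 150 nM).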

Compound 4, half-maximal effective concentration: 10 nM
Compound 4: the middle estimate sits 3.0-fold (0.48 log units) above what was measured; low and high end bracket the measured number.
By their numbers in this assay, from the lowest: compounds 4, 3 and 2 (each within the scatter of the next). At a limit, above all of these: compound 1.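

In this assay, the exchange of a six-membered aromatic ring for a five-membered one that brings a hydrogen-bond donor stays within the scatter (a 1.3-fold lower number from compound 3 to compound 4 (0.11 log units; within the scatter)) and does so against either pyridine (a 1.8-fold lower number from compound 2 to compound 4 (0.26 log units; within the scatter)). This place on the saturated chain carbon therefore accepts 1H-imidazol-5-yl as well as both pyridinyl groups in this series. Nothing at hand gives a cause for these steps.

Whether an aromatic ring is needed here at all remains open, as the compounds shown do not include a plain phenyl, a cyclohexyl or a simple methyl at this place. From the compounds shown here alone, the effect of a longer chain between the ring and the amino nitrogen also remains open.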